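Lengthening the chain between two guanidine groups

The compounds below may be only part of what the source reports. "The series", "measured", "known", "first", "only" and "open" are said of these compounds alone.

Compound 1 `N=C(N)Nc1ccc(OC(=O)c2ccc(N)cc2)cc1`: in an assay on isolated protein for inhibition of Trypsin (Homo sapiens), read by fluorescence, with a stated time of 15 min (on this read-out higher numbers stand for weaker inhibition and lower numbers for stronger inhibition), compound 1 gives 2.78 nM.
Compound 2 `N=C(N)NCCCOC(=O)c1ccc(NC(=N)N)cc1`: in this assay compound 2 gives 9840 nM.

Of these two numbers, compound 2 stands at the higher one, which here means the weaker inhibition. Among the compounds with values here, its only neighbour, compound 1, sits at a far lower number, and that gap lies well beyond the scatter of repeated measurements, so the two compounds behave very differently. Within the data shown here, no pair of measured compounds differs in a single place, so no measured single step is available as a guide.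

Compound 3 `N=C(N)NCCCCOC(=O)c1ccc(NC(=N)N)cc1` is the next compound. It differs from compound 2 by a group of 5 heavy atoms (2 carbon, 3 nitrogen; no ring) in place of a group of 4 heavy atoms (1 carbon, 3 nitrogen; no ring), on a saturated chain carbon, three bonds along the chain from an oxygen next to a carbonyl group, that is, the chain carrying the second guanidine grows by one carbon. A change of this kind gives no reason, from the numbers at hand, to expect a large move. The step from compound 2 to compound 3 in this assay is expected to be a 2.0-fold lower number from compound 2 to compound 3 (0.29 log units; within the scatter), at most a modest drift toward a lower number and possibly none beyond the scatter. Compound 3 is therefore expected to give 5000 nM, with a range from 1500 nM to 20000 nM.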

Compound 3, half-maximal inhibitory concentration: 8270 nM
The estimate for compound 3 lay 1.7-fold (0.22 log units) below the measured number; the measured number falls inside the stated range.
By their numbers in this assay, from the lowest: compound 1; then compounds 3 and 2 (each within the scatter of the next).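

In this assay, within the data shown here, the chain carrying the second guanidine grows by one carbon and the result is a 1.2-fold lower number from compound 2 to compound 3 (0.08 log units; within the scatter), the first single change in this set that can be read directly. At this saturated chain carbon, then, one extra carbon produces no shift that can be told apart from the ordinary scatter of repeated measurements, and compound 2 and compound 3 count as one level of inhibition. The data give no explanation for why the two chain lengths read alike.

Among these compounds, two chain lengths make only one step, so they cannot show whether the flat reading is a feature of this stretch of chain alone or would hold for a longer chain as well. Also open, as far as these compounds go, is how the value would respond to a change in the group itself, for instance an amine or a carboxylic acid in place of the second guanidine, rather than to a change in the length of the chain that carries it.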